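From a Five- to a Six-Membered Amide Ring

A few compounds are considered here, and "the series" means these few. Any claim that something is new, unique, unknown or untested is made for them only; others in the source may bear on it.

Three compounds built on one shared core have been measured in an assay on HEK293 cells for positive allosteric modulation of metabotropic glutamate receptor 5 (Homo sapiens), read by FLIPR, with a stated time of 1 h; on this read-out lower numbers stand for an effect already at smaller amounts and higher numbers for an effect only at larger amounts of compound:
compound 1, `CCCCN1CCc2nc(C#Cc3ccccc3)sc2C1`, gives 110 nM
compound 2, `CC1CC(C(=O)N2CCc3nc(C#Cc4ccccc4)sc3C2)C1`, gives 81 nM
compound 3, `O=C(C1CCCC1)N1CCc2nc(C#Cc3ccccc3)sc2C1`, gives 19 nM

Compound 3 stands lowest of the three in this assay: a 4.3-fold lower number from compound 2 to compound 3 (0.63 log units; beyond the scatter) and a 5.8-fold lower number from compound 1 to compound 3 (0.76 log units; beyond the scatter), both beyond the scatter, whereas a 1.4-fold lower number from compound 1 to compound 2 (0.13 log units; within the scatter). The next compound, compound 4, `O=C(C1CCCCC1)N1CCc2nc(C#Cc3ccccc3)sc2C1`, differs from compound 3 in one place: cyclohexyl in place of cyclopentyl on a carbonyl carbon. For the measured compounds named here, no measured step enlarges this ring in the same way. The nearest comparison is the earlier change on the carbonyl carbon, where a 4.3-fold lower number from compound 2 to compound 3 (0.63 log units; beyond the scatter); that step also added one ring carbon, and it brought a modest gain. Adding a further ring carbon might continue in that direction, but with one comparison only, a small gain or nothing beyond the scatter are both plausible. Compound 4 is therefore expected to give 14 nM, with a range from 5 nM to 45 nM. The expected step is a 1.4-fold lower number from compound 3 to compound 4 (0.13 log units; within the scatter).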

Compound 4, half-maximal effective concentration: 167 nM
Compound 4: middle estimate off by 12-fold (1.08 log units), on the low side, and the stated range ends below it.
By their numbers in this assay, from the lowest: compound 3; then compounds 2, 1 and 4 (each within the scatter of the next, the first and the last beyond it).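

At this carbonyl carbon, the step from cyclopentyl to cyclohexyl runs against the earlier gain, with an 8.8-fold higher number from compound 3 to compound 4 (0.94 log units; beyond the scatter), so one added ring carbon is enough to change the result markedly. The carbonyl does not carry the lower number by itself: against the butyl compound the cyclohexylcarbonyl step gives a 1.5-fold higher number from compound 1 to compound 4 (0.18 log units; within the scatter), and against the 3-methylcyclobutyl amide it gives a 2.1-fold higher number from compound 2 to compound 4 (0.31 log units; beyond the scatter). Of the three groups on this carbonyl carbon, only cyclopentyl gives a number beyond the scatter below that of the butyl compound, so the gain seen earlier belongs to that group and not to the amide in general.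

Nothing available here explains the difference between the two rings. On these data alone, it remains open how an unsubstituted cyclobutyl, a cycloheptyl or a tetrahydropyranyl ring would read on the same carbonyl carbon.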